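Amide nitrogen substituent: compound 1 to compound 4

The source may report more compounds than this note shows. Statements on the series, on what has been measured and on what is new or still open speak of the compounds shown alone.

Compound 1 `COc1ccc(Cl)cc1N(CC(=O)Nc1cccc2ccccc12)S(=O)(=O)c1ccccc1` gives 17400 nM in a functional assay on SH-SY5Y cells (Homo sapiens), read by MTT assay, with a stated time of 24 h; a lower number here means that less compound is needed, a higher number that more compound is needed for the effect. Among the numbers shown it stands highest, its nearest neighbour being compound 2 `COc1ccc(NC(=O)CN(c2cc(Cl)ccc2OC)S(=O)(=O)c2ccccc2)cc1`, which in this assay gives 16200 nM; the step of a 1.1-fold lower number from compound 1 to compound 2 (0.03 log units; within the scatter) is 4-methoxyphenyl in place of naphthalen-1-yl on an amide-type nitrogen. Compound 3 `COc1ccc(CNC(=O)CN(c2cc(Cl)ccc2OC)S(=O)(=O)c2ccccc2)cc1` reaches only a limit in this assay, > 20000 nM. That limit is recorded as the limit of > 20000 nM in this assay, at which 1 of the 3 values shown sits. The steps of an at least 1.1-fold higher number from compound 1 to compound 3 (0.06 log units; that floor lies within the scatter) and an at least 1.2-fold higher number from compound 2 to compound 3 (0.09 log units; that floor lies within the scatter) are therefore floors only.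

Compound 4 `COc1ccc(Cl)cc1N(CC(=O)NC1CCCCC1)S(=O)(=O)c1ccccc1` is not yet measured. It differs from compound 1 by cyclohexyl in place of naphthalen-1-yl on an amide-type nitrogen. For the measured compounds named here, no measured step involves a cyclohexyl group; the two replacements on that nitrogen so far left the number within the scatter or took it to the limit, so no step beyond the scatter is expected in this assay, with a real chance that only a limit is returned. Compound 4 is estimated at 20000 nM, within 10000 nM to 40000 nM. The expected step is a 1.1-fold higher number from compound 1 to compound 4 (0.06 log units; within the scatter).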

Compound 4, half-maximal effective concentration: 17600 nM
Beside the measured number, compound 4's estimate is 1.1-fold (0.06 log units) above it; the measured number falls inside the stated range.
By their numbers in this assay, from the lowest: compounds 2, 1 and 4 (each within the scatter of the next). At a limit, above all of these: compound 3.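

Cyclohexyl brings a non-aromatic ring onto this amide-type nitrogen, and the steps of a 1.0-fold higher number from compound 1 to compound 4 (0.00 log units; within the scatter) and a 1.1-fold higher number from compound 2 to compound 4 (0.04 log units; within the scatter) show that a number of this size in this assay does not depend on an aromatic ring at this place. Compound 3 remains at a limit of the assay: the limit of > 20000 nM in this assay, at which 1 of the 4 values shown sits.

The step of an at least 1.1-fold lower number from compound 3 to compound 4 (0.05 log units; that floor lies within the scatter) is a floor only and does not settle how 4-methoxybenzyl and cyclohexyl compare.

Still open is whether any group on this nitrogen can take the number in this assay beyond the scatter, since the groups shown are all ring groups of similar outcome. A short chain such as ethyl, a chain ending in an amine or a carboxylic acid would test this.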